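The source may report more compounds than this note shows. Statements on the series, on what has been measured and on what is new or still open speak of the compounds shown alone.

Compound 1 `Cn1c(Cc2nn(C)c(=O)c3ccccc23)nnc1SCCCCCCCCCCCCCCCC(=O)Nc1ccc(Cl)cc1Cl`: 7300 nM
Compound 2 `Cn1c(Cc2nn(C)c(=O)c3ccccc23)nnc1SCCCCCCCC(=O)Nc1ccc(Cl)cc1Cl`: 1900 nM
Compound 3 `Cn1c(Cc2nn(C)c(=O)c3ccccc23)nnc1SCC(=O)Nc1ccc(Cl)cc1Cl`: 17300 nM

All three were tested in an assay on isolated protein (Mus musculus) for inhibition of IL15-IL15 receptor (Homo sapiens), read by resazurin assay, with stated times of 30 min and 2.5 days; on this read-out lower numbers stand for stronger inhibition and higher numbers for weaker inhibition. Compound 2 gives the lowest number of the three; compound 1 stands beyond the scatter from it, and compound 3 further still. Compound 4 `COc1ccc(NC(=O)CCCCCCCSc2nnc(Cc3nn(C)c(=O)c4ccccc34)n2C)cc1` has not yet been measured. It differs from compound 2 in one place: 4-methoxyphenyl in place of 2,4-dichlorophenyl on an amide-type nitrogen. Going by the values given here, no measured pair shows this same change, so nothing in the present data tells how it plays out. The expectation for compound 4 is a modest weakening, roughly at the edge of the scatter, expressed as the step of a 1.8-fold higher number from compound 2 to compound 4 (0.27 log units; within the scatter). The estimated value for compound 4 in this assay is 3500 nM, with a range from 1200 nM to 11000 nM.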

Compound 4, half-maximal inhibitory concentration: 3900 nM
Estimate against measurement, compound 4: 1.1-fold (0.05 log units) below, and the stated range covers the measured number.
By their numbers in this assay, from the lowest: compound 2; then compounds 4 and 1 (each within the scatter of the next); then compound 3.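

In this assay, compounds 1, 2 and 3 all carry 2,4-dichlorophenyl, so they said nothing about the group on the amide-type nitrogen. Replacing it with 4-methoxyphenyl costs only modest strength, a 2.1-fold higher number from compound 2 to compound 4 (0.31 log units; beyond the scatter), so inhibition at this level does not depend on the two chlorine atoms. No measurement here accounts for this step. Still open, on these data alone, is how a plain phenyl, or a phenyl bearing an amine or a carboxylic acid, would fare at this place. Also open, as far as these compounds go, is whether the change would give a similar step on the longer chain of compound 1 or the shorter chain of compound 3.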